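The source may hold more compounds than are shown below. What is called first, only, known or untested is meant among the compounds shown, and "the series" means these compounds.

Compound 1 `Cc1ccnc(-c2cnc(C(=O)CCCCCCc3ccccc3)o2)c1` gives 0.6 nM in an assay (Rattus norvegicus) for inhibition of Fatty-acid amide hydrolase 1 (Homo sapiens); on this read-out lower numbers stand for stronger inhibition and higher numbers for weaker inhibition. Compound 2 `NC(=O)c1ccc(-c2cnc(C(=O)CCCCCCc3ccccc3)o2)nc1` gives 1.2 nM. Compound 3 `CNC(=O)c1cnc(C(=O)CCCCCCc2ccccc2)o1` gives 7 nM.

Compound 3 has the highest number of the three; the step to its nearest neighbour is a 5.8-fold higher number from compound 2 to compound 3 (0.77 log units; beyond the scatter), and to the furthest it is a 12-fold higher number from compound 1 to compound 3 (1.07 log units; beyond the scatter). Compound 4 `O=C(CCCCCCc1ccccc1)c1ncc(I)o1` is not yet measured. The change from compound 3 to compound 4 is iodo in place of methylcarbamoyl on an aromatic carbon. The two measured steps that touch this place, a 12-fold higher number from compound 1 to compound 3 (1.07 log units; beyond the scatter) and a 5.8-fold higher number from compound 2 to compound 3 (0.77 log units; beyond the scatter), both concern a methylcarbamoyl replacing a substituted pyridyl group; neither shows what a single iodo does there, so they bear on the step only loosely. The data show that a large aromatic group at this place keeps the number low, while the methylcarbamoyl raises it. Since iodo is smaller still and carries no hydrogen-bond donor or acceptor, compound 4 is expected to sit somewhat higher than compound 3, with an estimated step of a 4.3-fold higher number from compound 3 to compound 4 (0.63 log units; beyond the scatter). Compound 4 is thus estimated at 30 nM, in a range from 5 nM to 150 nM.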

Compound 4, inhibition constant: 3 nM
Estimate against measurement, compound 4: 10-fold (1.00 log units) above, outside the stated range (below it).
By their numbers in this assay, from the lowest: compounds 1 and 2 (each within the scatter of the next); then compound 4; then compound 3.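

In this assay, a single iodo on the aromatic carbon next to the ring oxygen does better than methylcarbamoyl, with a 2.3-fold lower number from compound 3 to compound 4 (0.37 log units; beyond the scatter), so at this place one heavy atom and no hydrogen-bond donor or acceptor do not bring a higher number. The order therefore does not follow group size throughout: the 5-carbamoylpyridin-2-yl and 4-methylpyridin-2-yl groups still hold the lower numbers, with a 2.5-fold higher number from compound 2 to compound 4 (0.40 log units; beyond the scatter) and a 5.0-fold higher number from compound 1 to compound 4 (0.70 log units; beyond the scatter), yet methylcarbamoyl, larger than iodo, gives the highest number of the four. No measurement at hand accounts for why iodo and methylcarbamoyl differ in this way.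

As far as these compounds go, it remains open whether chloro or bromo at this place would behave like iodo. Also open, from the compounds shown here alone, is whether a plain phenyl ring would match the two pyridyl groups.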